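Adding a bromo to compound 2

The source may report more compounds than this note shows. Statements on the series, on what has been measured and on what is new or still open speak of the compounds shown alone.

In a functional assay on SW480 cells (Homo sapiens) for antiproliferative activity, read by MTT assay, with a stated time of 48 h (on this read-out lower numbers stand for stronger inhibition and higher numbers for weaker inhibition), compound 1 `CCCCCCC(CCO)n1c(Br)nc2c(Cl)ncnc21` gives 14100 nM and compound 2 `CCCCCCCC(CCO)n1cnc2c(Cl)ncnc21` gives 3630 nM. Compound 2 therefore holds the lower of the two numbers, and the gap between them lies beyond the usual scatter. Compound 3 `CCCCCCCC(CCO)n1c(Br)nc2c(Cl)ncnc21` departs from compound 2 in a single place: bromo in place of hydrogen on an aromatic carbon, a bromo in place of hydrogen on an aromatic carbon. Among the compounds with values here, no measured pair shows this change on its own, so its size is uncertain. Within the data shown here, the only measured compound that carries this bromo is compound 1, at 14100 nM, which points to a moderate rise rather than a fall. The estimated change a 1.9-fold higher number from compound 2 to compound 3 (0.29 log units; within the scatter) would mean somewhat weaker inhibition in this assay. For compound 3 the expected value is 7000 nM, with an estimated range of 2500 nM to 20000 nM.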

Compound 3, half-maximal inhibitory concentration: 14400 nM
Beside the measured number, compound 3's estimate is 2.1-fold (0.31 log units) below it; low and high end bracket the measured number.
By their numbers in this assay, from the lowest: compound 2; then compounds 1 and 3 (each within the scatter of the next).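

Within the data shown here, compound 3 gives the first clean reading of this change in this assay: placing a bromo on the aromatic carbon between two ring nitrogen atoms brings a 4.0-fold higher number from compound 2 to compound 3 (0.60 log units; beyond the scatter) and so means weaker inhibition, whereas the earlier pair differed in more than one place. With the bromo in place, a methyl in place of hydrogen on a saturated chain carbon, seven bonds along the chain from an aromatic nitrogen, gives a 1.0-fold higher number from compound 1 to compound 3 (0.01 log units; within the scatter) and so leaves the reading unchanged within the usual scatter. Nothing measured here explains why the bromo weakens inhibition.

Going by these compounds, whether a smaller fluoro, a methyl or an amine on that same aromatic carbon would behave like the bromo stays open. So does whether a longer chain would matter, with or without the bromo.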